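The compounds below may be only part of what the source reports. "The series", "measured", "known", "first", "only" and "open" are said of these compounds alone.

Measured compounds, with their values in a functional assay on PC-3 cells (Homo sapiens) for antiproliferative activity, read by MTT assay, with a stated time of 48 h; on this read-out lower numbers stand for stronger inhibition and higher numbers for weaker inhibition:
compound 1 `O=C(/C=C\Nc1ccc(O)cc1)c1cn(-c2ccccc2)nc1-c1ccc(Cl)cc1`: 4430 nM
compound 2 `COc1ccc(N/C=C\C(=O)c2cn(-c3ccccc3)nc2-c2ccc(Cl)cc2)cc1`: 10700 nM
compound 3 `COc1ccc(-c2nn(-c3ccccc3)cc2C(=O)/C=C\Nc2ccc(O)cc2)cc1`: 1980 nM

Compound 3 gives the lowest of the three numbers; its nearest neighbour is compound 1, and compound 2 lies furthest from it, both gaps beyond the scatter.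

Two changes are tracked in this set. For the measured compounds named here, the first is the change of core: compound 1 and compound 3 differ by methoxy in place of chloro on an aromatic carbon, and that difference produced a 2.2-fold lower number from compound 1 to compound 3 (0.35 log units; beyond the scatter).

The second is a change on the other side of the molecule. Compound 1 and compound 2 differ by methyl in place of hydrogen on an oxygen on an aromatic ring, which produced a 2.4-fold higher number from compound 1 to compound 2 (0.38 log units; beyond the scatter).

Compound 4 `COc1ccc(N/C=C\C(=O)c2cn(-c3ccccc3)nc2-c2ccc(OC)cc2)cc1` has not yet been measured. It differs from compound 3 by methyl in place of hydrogen on an oxygen on an aromatic ring. The place of this change is the same, word for word, as the place of the change from compound 1 to compound 2, so it is the same change, carried over onto the core of compound 3. Going by the values given here, the only guide to its size is the single measured instance of this change, a 2.4-fold higher number from compound 1 to compound 2 (0.38 log units; beyond the scatter), and with one instance there is no way to tell whether the core of compound 3 would alter the outcome.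

On that basis the expected step in this assay is a 2.4-fold higher number from compound 3 to compound 4 (0.38 log units; beyond the scatter), taken directly from the size of a 2.4-fold higher number from compound 1 to compound 2 (0.38 log units; beyond the scatter). Compound 4 is therefore estimated at 4700 nM, with a plausible range from 2500 nM to 9000 nM.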

Compound 4, half-maximal inhibitory concentration: 13400 nM
For compound 4 the middle estimate is 2.9-fold (0.46 log units) below the measured one; measured number outside the range, above it.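

In this assay, hydroxy to methoxy gives a higher number on both cores, and the new instance, a 6.8-fold higher number from compound 3 to compound 4 (0.83 log units; beyond the scatter), shows that the direction carries over but the size does not: the same change on two cores in this assay, a 2.4-fold higher number (0.38 log units; beyond the scatter) from compound 1 to compound 2 and a 6.8-fold higher number (0.83 log units; beyond the scatter) from compound 3 to compound 4, 2.8-fold (0.45 log units) apart, beyond the scatter of two such steps

Methoxy in place of chloro on an aromatic carbon also depends on its partner, since with (4-methoxyphenyl)amino in the molecule it gives a 1.3-fold higher number from compound 2 to compound 4 (0.10 log units; within the scatter), and the lower number seen with (4-hydroxyphenyl)amino does not recur: the same change on two cores in this assay, a 2.2-fold lower number (0.35 log units; beyond the scatter) from compound 1 to compound 3 and a 1.3-fold higher number (0.10 log units; within the scatter) from compound 2 to compound 4, 2.8-fold (0.45 log units) apart, beyond the scatter of two such steps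

These four compounds form a single square, so the two gaps describe one dependence between the two places rather than two independent findings, and they show neither a cause nor how either change would behave on any further core.

The compounds shown leave open whether the larger penalty for methoxy persists when the aromatic carbon carries another group, such as fluoro or an amine, in place of chloro or methoxy. They also leave open how an amine, a carboxylic acid or a longer chain such as ethoxy would compare with hydroxy and methoxy on either core.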